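Methoxy for Chloro on a Pyridine Amide Against Melanoma Cells

The source may report more compounds than this note shows. Statements on the series, on what has been measured and on what is new or still open speak of the compounds shown alone.

Three compounds on a shared core were tested in a functional assay on WM 266-4 cells (Homo sapiens) for antiproliferative activity, read by MTT assay, with a stated time of 48 h; on this read-out lower numbers stand for stronger inhibition and higher numbers for weaker inhibition. Compound 1 `Cc1ccc(-c2cc(NC(=O)c3cccnc3Cl)n[nH]2)cc1` gives 5350 nM. Compound 2 `COc1ncccc1C(=O)Nc1cc(-c2ccc(C)cc2)[nH]n1` gives 7760 nM. Compound 3 `Cc1ccc(-c2cc(NC(=O)c3ccc(Cl)nc3)n[nH]2)cc1` gives 5720 nM. Compound 3 differs from compound 1 in how the core is joined: 6-chloropyridin-3-yl in place of 2-chloropyridin-3-yl on a carbonyl carbon, and this gave a 1.1-fold higher number from compound 1 to compound 3 (0.03 log units; within the scatter). Compound 2 differs from compound 1 by methoxy in place of chloro on an aromatic carbon, and this gave a 1.5-fold higher number from compound 1 to compound 2 (0.16 log units; within the scatter). Compound 4 `COc1ccc(C(=O)Nc2cc(-c3ccc(C)cc3)[nH]n2)cn1` has not yet been measured; it differs from compound 3 by methoxy in place of chloro on an aromatic carbon. This is the same kind of change as that between compound 1 and compound 2, but the surroundings differ: in compound 2 the methoxy sits ortho to a large group, while in compound 4 it sits para to a large group. Because the earlier change gave a 1.5-fold higher number from compound 1 to compound 2 (0.16 log units; within the scatter), a step of similar size is expected for compound 4, estimated as a 1.4-fold higher number from compound 3 to compound 4 (0.15 log units; within the scatter). Compound 4 is therefore expected to give about 8000 nM, most likely between 4000 nM and 16000 nM.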

Compound 4, half-maximal inhibitory concentration: 7350 nM
The estimate for compound 4 lay 1.1-fold (0.04 log units) above the measured number; the range from low to high includes it.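

In this assay, methoxy in place of chloro on the second core gave a 1.3-fold higher number from compound 3 to compound 4 (0.11 log units; within the scatter), so this step, like the earlier one, cannot be told apart from repeat-measurement noise. Set side by side, the two steps agree: the same change on two cores in this assay, a 1.5-fold higher number (0.16 log units; within the scatter) from compound 1 to compound 2 and a 1.3-fold higher number (0.11 log units; within the scatter) from compound 3 to compound 4, 1.1-fold (0.05 log units) apart, within the scatter of two such steps

Within these two pairs, then, the change carries from one core to the other without a step that stands out, but this is agreement between two small steps, and neither step shows a real difference between methoxy and chloro, nor does either say how the swap would behave on any other core.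

The compounds shown leave open whether any group at this place on the ring can move the number beyond the scatter, for instance an amine or a carboxylic acid in place of chloro or methoxy. From the compounds shown here alone, it also remains open whether a longer chain, such as ethoxy or propoxy, would follow the methoxy compounds or part from them.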